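Swapping 3-aminopyrrolidin-1-yl for 3-aminopiperidin-1-yl on compound 3

The source may report more compounds than this note shows. Statements on the series, on what has been measured and on what is new or still open speak of the compounds shown alone.

Of the compounds shown here, three with a shared core have been measured in a physicochemical assay for solubility, read by LC-MS, in phosphate buffer, with a stated time of 24 h, at pH 7.4; a higher number here means a more soluble compound, a lower number a less soluble compound. Compound 1 `CC(=O)Nc1cc(Nc2cc(NC3CC3)n3ncc(C#N)c3n2)ccc1NCCCO` gives 2000 nM. Compound 2 `CCN(CCN)c1ccc(Nc2cc(NC3CC3)n3ncc(C#N)c3n2)cc1NC(C)=O` gives > 1000000 nM, which is a limit of the assay and not a number. Compound 3 `CC(=O)Nc1cc(Nc2cc(NC3CC3)n3ncc(C#N)c3n2)ccc1N1CC[C@@H](N)C1` gives 812000 nM, the higher of the two actual numbers.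

Compound 4 `CC(=O)Nc1cc(Nc2cc(NC3CC3)n3ncc(C#N)c3n2)ccc1N1CCC[C@H](N)C1` has not yet been measured. It carries 3-aminopiperidin-1-yl in place of 3-aminopyrrolidin-1-yl on an aromatic carbon, ortho to an acetamido group: 3-aminopiperidin-1-yl in place of 3-aminopyrrolidin-1-yl on an aromatic carbon. The amino group stays, and the ring goes from five-membered to six-membered.

Among the measured compounds shown here, all the measured steps changed this same place. Two were large: an at least 500-fold higher number from compound 1 to compound 2 (2.69 log units; beyond the scatter), and a 410-fold higher number from compound 1 to compound 3 (2.61 log units; beyond the scatter). Both replaced the group of compound 1, so they show how much this place can matter, but neither compares two close relatives. The third step is nearer to the new change: an at least 1.2-fold lower number from compound 2 to compound 3 (0.09 log units; that floor lies within the scatter). That change of group shows no gap that can be claimed beyond the scatter, so only a modest shift is expected here, with no step beyond the scatter. The expected step is a 1.6-fold lower number from compound 3 to compound 4 (0.21 log units; within the scatter). For compound 4 the estimate is 500000 nM, with an expected range from 150000 nM to 1000000 nM.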

Compound 4, solubility: 704000 nM
The estimate for compound 4 lay 1.4-fold (0.15 log units) below the measured number; the range from low to high includes it.
By their numbers in this assay, from the lowest: compound 1; then compounds 4 and 3 (each within the scatter of the next). At a limit, above all of these: compound 2.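

In this assay, going from the five-membered 3-aminopyrrolidin-1-yl to the six-membered 3-aminopiperidin-1-yl leaves two compounds that cannot be told apart (a 1.2-fold lower number from compound 3 to compound 4 (0.06 log units; within the scatter)). Among the compounds shown here, this is the first comparison of two rings of different size at this position, and it shows that the ring size, at these two sizes, does not decide the reading: the large distance from the (3-hydroxypropyl)amino group of compound 1 holds for the six-membered ring too (a 350-fold higher number from compound 1 to compound 4 (2.55 log units; beyond the scatter)), while the open-chain amine of compound 2 offers no gap that can be claimed (an at least 1.4-fold lower number from compound 2 to compound 4 (0.15 log units; that floor lies within the scatter)). That comparison has only one firm end, as compound 2 stands at a limit of the assay and not at a number: the limit of > 1000000 nM in this assay, at which 1 of the 4 values shown sits.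

From the compounds shown here alone, what the amino group on the ring contributes stays open, and a plain piperidin-1-yl ring, or a carboxylic acid in place of the amine, would test it. Also open, going by these compounds, are the mirror-image form at the defined stereocentre and whether a seven-membered ring or a longer chain ending in an amine gives a similar reading in this assay at this place.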